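Series notes: coumarin ethers against monoamine oxidase A

A few compounds are considered here, and "the series" means these few. Any claim that something is new, unique, unknown or untested is made for them only; others in the source may bear on it.

Of the compounds shown here, three have been measured in an assay on isolated protein (strain Sprague-Dawley) for inhibition of Amine oxidase [flavin-containing] A (Rattus norvegicus), read by spectrophotometry, with a stated time of 5 min, tested at 10 uM; on this read-out lower numbers stand for less inhibition and higher numbers for more inhibition at the one concentration tested (going by the name of the read-out). Compound 1 `CCCOc1cc(=O)oc2cc(OCc3ccccc3)ccc12` gives 0%, compound 2 `CCCOc1cc(=O)oc2cc(OCc3cccc(F)c3)ccc12` gives 12%, and compound 3 `CC(=O)COc1cc(=O)oc2cc(OCc3cccc(Cl)c3)ccc12` gives 22%. Compound 3 holds the top number of the three, yet compound 2 sits within the scatter of it; only compound 1 lies clearly lower. The one single-point step shown, a number 12 percentage points higher from compound 1 to compound 2 (beyond the scatter), concerns fluoro in place of hydrogen and does not touch the part changed next.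

Compound 4 `O=C(O)c1cc(=O)oc2cc(OCc3cccc(Cl)c3)ccc12` differs from compound 3 as follows: carboxy in place of 2-oxopropoxy on an aromatic carbon. For the measured compounds named here, no measured step covers this exchange, so no change beyond the scatter is expected in this assay; the estimated step is a number 8 percentage points lower from compound 3 to compound 4 (within the scatter). Compound 4 is therefore expected to give about 14%, within 0% to 32%.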

Compound 4, a percentage reported as inhibition, at one concentration (the size of the read-out at that concentration, not a potency): 0%
The estimate for compound 4 lay 14 percentage points above the measured number, and the stated range covers the measured number.
By their numbers in this assay, from the lowest: compounds 1 and 4 (each within the scatter of the next); then compounds 2 and 3 (each within the scatter of the next).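

In this assay, the position opposite the ring oxygen proves sensitive to what it carries: carboxy in place of 2-oxopropoxy gives a number 22 percentage points lower from compound 3 to compound 4 (beyond the scatter), the first step read at this position. The earlier step, fluoro in place of hydrogen, lay in another part of the structure and said nothing about this one. No measurement at hand bears on why the number falls here.

Still open, going by these compounds, is whether an amide, a methyl ester or a longer ether chain at this position would stay level with compound 3. On these data alone, it is also open whether a bromo or methoxy group in place of the chloro would shift the number.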